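Amino in place of chloro on a shared core

The source may report more compounds than this note shows. Statements on the series, on what has been measured and on what is new or still open speak of the compounds shown alone.

Compound 1, `Nc1nc(Cl)c2ncn(Cc3ccc(CCl)cc3)c2n1`, gives 500 nM in a functional assay on HCC 2998 cells (Homo sapiens) for cytotoxicity, read by sulforhodamine B assay, with a stated time of 48 h; on this read-out lower numbers stand for stronger inhibition of growth and higher numbers for weaker inhibition of growth.
Compound 2, `ClCc1cccc(Cn2cnc3c(Cl)nc(Cl)nc32)c1`, gives 1620 nM in this assay.
Compound 3, `ClCc1ccc(Cn2cnc3c(Cl)nc(Cl)nc32)cc1`, gives 10200 nM in this assay.

Compound 2 and compound 3 are built from the same atoms joined differently; the difference between the two cores is not broken down here. Compound 2 stands second of the three, with compound 1 giving a lower number and compound 3 a higher one, each gap beyond the scatter. Compound 3 and compound 1 differ in a single place: amino in place of chloro on an aromatic carbon. That change produced a 20-fold lower number from compound 3 to compound 1 (1.31 log units; beyond the scatter), a large step.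

Compound 4, `Nc1nc(Cl)c2ncn(Cc3cccc(CCl)c3)c2n1`, has not yet been measured in this assay. It differs from compound 2 by amino in place of chloro on an aromatic carbon, which is the same change at the same place as the one just described. Going by the values given here, the step from compound 2 to compound 4 is expected to be an 11-fold lower number from compound 2 to compound 4 (1.03 log units; beyond the scatter), somewhat short of the earlier one, since that rests on the single step of a 20-fold lower number from compound 3 to compound 1 (1.31 log units; beyond the scatter) and its full size may not carry over. Compound 4 is therefore expected to give about 150 nM, likely between 50 nM and 500 nM.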

Compound 4, concentration for 50% growth inhibition: 3020 nM
Estimate against measurement, compound 4: 20-fold (1.30 log units) below; measured number outside the range, above it.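

In this assay, going by these compounds alone, amino in place of chloro on an aromatic carbon did not repeat its earlier large effect on the second core: the change gave a 1.9-fold higher number from compound 2 to compound 4 (0.27 log units; within the scatter), so this pair shows no step that can be told from the scatter. Set side by side, the two results differ: the same change on two cores in this assay, a 20-fold lower number (1.31 log units; beyond the scatter) from compound 3 to compound 1 and a 1.9-fold higher number (0.27 log units; within the scatter) from compound 2 to compound 4, 38-fold (1.58 log units) apart, beyond the scatter of two such steps. This shows that, among these four compounds, the size of the step depends on the core that carries it, so the effect seen on one of these two cores cannot simply be carried over to the other, but two pairs do not show which feature of the cores separates the results, nor how the change would behave on any further core.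

The compounds shown leave open whether a methylamino or hydroxyl group in place of the amino would follow either pair. They also leave open how the change would behave on either core with a hydroxymethyl group in place of the chloromethyl group.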